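Moving from 3,4-dichlorophenyl to 2-chloro-4-fluorophenyl

The source may hold more compounds than are shown below. What is called first, only, known or untested is meant among the compounds shown, and "the series" means these compounds.

In a functional assay on HepG2 cells (Homo sapiens) for antiproliferative activity, read by MTT assay, with a stated time of 72 h (a lower number here means a stronger inhibitor, a higher number a weaker inhibitor), compound 3 `O=C(N/N=C/c1ccc(Cl)c(Cl)c1)Nc1ccc(Oc2ccnc3[nH]ccc23)c(F)c1` gives 3700 nM and sits level with compound 2 `O=C(N/N=C/c1ccc(F)cc1)Nc1ccc(Oc2ccnc3[nH]ccc23)c(F)c1` at 3880 nM while compound 1 `O=C(N/N=C/c1cccc(Br)c1)Nc1ccc(Oc2ccnc3[nH]ccc23)c(F)c1` stands apart at 660 nM on the stronger side. Compound 4 `O=C(N/N=C/c1ccc(F)cc1Cl)Nc1ccc(Oc2ccnc3[nH]ccc23)c(F)c1` follows from compound 3 through the change 2-chloro-4-fluorophenyl in place of 3,4-dichlorophenyl on a carbon with a double bond to nitrogen that puts 2-chloro-4-fluorophenyl in place of 3,4-dichlorophenyl on a carbon with a double bond to nitrogen. The closest guide is a 1.0-fold lower number from compound 2 to compound 3 (0.02 log units; within the scatter) which stayed within the scatter, so no step beyond the scatter is expected in this assay for this change. The modest steps of a 5.9-fold higher number from compound 1 to compound 2 (0.77 log units; beyond the scatter) and a 5.6-fold higher number from compound 1 to compound 3 (0.75 log units; beyond the scatter) both leave 3-bromophenyl, a group compound 4 also lacks. The expected step of a 1.2-fold lower number from compound 3 to compound 4 (0.09 log units; within the scatter) stays inside the scatter. Compound 4 is estimated at 3000 nM with 900 nM to 8000 nM as the expected range.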

Compound 4, half-maximal inhibitory concentration: 1110 nM
Compound 4: middle estimate off by 2.7-fold (0.43 log units), on the high side; measured number inside the range.
By their numbers in this assay, from the lowest: compounds 1 and 4 (each within the scatter of the next); then compounds 3 and 2 (each within the scatter of the next).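

Until now, only 3-bromophenyl stood apart at this place, but in this assay chloro in place of hydrogen on an aromatic carbon gives a 3.5-fold lower number from compound 2 to compound 4 (0.54 log units; beyond the scatter), and replacing 3,4-dichlorophenyl gives a 3.3-fold lower number from compound 3 to compound 4 (0.52 log units; beyond the scatter). So 3-bromophenyl is not the only group here on the stronger side of compounds 2 and 3: a 1.7-fold higher number from compound 1 to compound 4 (0.23 log units; within the scatter) stays within the scatter. No measurement offered here explains these steps.

Going by these compounds, whether 2-chlorophenyl alone would give the same step stays open. So does the effect of an amine or a longer chain on this carbon.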